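A few compounds are considered here, and "the series" means these few. Any claim that something is new, unique, unknown or untested is made for them only; others in the source may bear on it.

Of the compounds shown here, three with a shared core have been measured in an ADME assay on microsomes from liver (Homo sapiens) for metabolic stability, read by LC-MS, tested at 1 uM; a lower number here means slower removal, a higher number faster removal of the compound. Compound 1 `c1cc([C@H]2CC[C@]3(CC2)OOC2(O3)C3CC4CC(C3)CC2C4)ccc1OCCCNC1CCOCC1` gives 10 mL.min-1.g-1, and compound 2 `CC(C)(O)CNCCCOc1ccc([C@H]2CC[C@]3(CC2)OOC2(O3)C3CC4CC(C3)CC2C4)cc1` gives 8 mL.min-1.g-1. The step between them is a 1.3-fold lower number from compound 1 to compound 2 (0.10 log units; within the scatter). Compound 3 `NC1CCN(S(=O)(=O)c2ccc([C@H]3CC[C@]4(CC3)OOC3(O4)C4CC5CC(C4)CC3C5)cc2)CC1` gives no exact number, only a limit of < 7 mL.min-1.g-1, which is the limit of < 7 mL.min-1.g-1 in this assay, at which 1 of the 3 values shown sits.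

Compound 4 `N[C@H]1CC[C@@H](Oc2ccc([C@H]3CC[C@]4(CC3)OOC3(O4)C4CC5CC(C4)CC3C5)cc2)CC1` differs from compound 3 by a single change at an aromatic carbon, para to a large group: (4-aminocyclohexyl)oxy in place of (4-aminopiperidin-1-yl)sulfonyl, ((4-aminocyclohexyl)oxy in place of (4-aminopiperidin-1-yl)sulfonyl on an aromatic carbon).

Among the measured compounds shown here, two measured steps bear most closely on this change. Both end on the same (4-aminopiperidin-1-yl)sulfonyl group and start from a group joined to the aromatic carbon through oxygen, as the entering group is. The first is an at least 1.4-fold lower number from compound 1 to compound 3 (0.15 log units; that floor lies within the scatter), and the second is an at least 1.1-fold lower number from compound 2 to compound 3 (0.05 log units; that floor lies within the scatter). Neither shows a shift beyond the scatter, although each gives only a minimum size. Run in reverse, they suggest that compound 4 may land close to compound 1 and compound 2, so a small rise is the likelier direction, with no clear step beyond the scatter expected. The estimate amounts to an expected at least 1.4-fold higher number from compound 3 to compound 4 (0.15 log units; that floor lies within the scatter). In this assay, the estimated value for compound 4 is 10 mL.min-1.g-1, with an expected range from 6 mL.min-1.g-1 to 20 mL.min-1.g-1.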

Compound 4, intrinsic clearance in microsomes: < 7 mL.min-1.g-1
Compound 4 gave a limit, no number (the forecaster's own chance of this, stated with the estimate: 20%); middle value at least 1.4-fold (0.15 log units) away from the limit.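

In this assay compound 4 sits at a limit and not at a number: the limit of < 7 mL.min-1.g-1 in this assay, at which 2 of the 4 values shown sit. Until now, only the (4-aminopiperidin-1-yl)sulfonyl group of compound 3 had reached that limit, so this result shows that a group joined through oxygen at this aromatic carbon, para to a large group, can reach it too, without the sulfonyl group. Changing what sits on that oxygen gives an at least 1.4-fold lower number from compound 1 to compound 4 (0.15 log units; that floor lies within the scatter) and an at least 1.1-fold lower number from compound 2 to compound 4 (0.05 log units; that floor lies within the scatter) as the two steps, and as each is only a minimum size, neither shows how large the real change is.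

Going by these compounds, the step from compound 3 to compound 4 cannot be read, since both ends are limits, so whether these two compounds differ at all stays open. Also open, on these data alone, is whether a 4-hydroxycyclohexyl group on the same oxygen, with a hydroxyl in place of the amine, would stay at this limit or return to a measurable number.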